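Swapping Methoxy for Nitro on a Thiosemicarbazide Tail

The compounds below may be only part of what the source reports. "The series", "measured", "known", "first", "only" and "open" are said of these compounds alone.

Of the compounds shown here, three have been tested in a functional assay on the whole organism (strain albino) for inhibition, with Rattus norvegicus as the target, read by paw edema, with stated times of 2 h and 1 h, at a dose of 100 mg/kg by the oral route; a higher number here means more inhibition at the dose given (going by the name of the read-out), a lower number less inhibition. Compound 1 `Cc1cc(C)n(Cc2n[nH]c(=S)o2)n1` gives 21.5%, and compound 2 `Cc1cccc(NC(=S)NNC(=O)Cn2nc(C)cc2C)c1` gives 22.9%. Compound 3 `COc1ccc(NC(=S)NNC(=O)Cn2nc(C)cc2C)cc1` gives 41.4%, the highest of the three, and its margin over compound 2 and over compound 1 lies beyond the usual scatter of this assay.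

Compound 4 `Cc1cc(C)n(CC(=O)NNC(=S)Nc2ccc([N+](=O)[O-])cc2)n1` has not yet been measured. It differs from compound 3 in one place: nitro in place of methoxy on an aromatic carbon. Among the measured compounds shown here, no measured pair shows a change of this kind, so there is no direct guide to its effect. The step expected from compound 3 to compound 4 is a modest one, downward or none beyond the scatter, given as a number 6.4 percentage points lower from compound 3 to compound 4 (within the scatter). Compound 4 is therefore estimated at 35%, within a range from 20% to 50%.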

Compound 4, a percentage reported as inhibition, in the whole organism at one dose (the size of the read-out at that dose, not a potency): 44.4%
The estimate for compound 4 lay 9.4 percentage points below the measured number; low and high end bracket the measured number.
By their numbers in this assay, from the lowest: compounds 1 and 2 (each within the scatter of the next); then compounds 3 and 4 (each within the scatter of the next).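

In this assay, putting nitro in place of methoxy on the aromatic carbon para to a large group gives a number 3 percentage points higher from compound 3 to compound 4 (within the scatter) and so leaves the read-out unchanged. Among the compounds shown here, this position therefore accepts either of these two quite different groups, a point the earlier compounds could not show because none of them formed such a pair. Nothing available explains why the two groups read alike.

As far as these compounds go, whether an amine or a carboxylic acid at the same position would match them remains open. So does the result of a bare hydrogen there.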